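A few compounds are considered here, and "the series" means these few. Any claim that something is new, unique, unknown or untested is made for them only; others in the source may bear on it.

Compound 1 `CCCNC(=O)c1c(CN(CC)Cc2ccccc2)nc2ccccc2c1-c1ccccc1` and compound 2 `CCN(Cc1ccccc1)Cc1nc2ccccc2c(-c2ccccc2)c1C(=O)N(C)C` share one core and differ only at the amide. In an assay on brain with Translocator protein (Rattus norvegicus) as the target (on this read-out lower numbers stand for stronger inhibition and higher numbers for weaker inhibition), compound 1 gives 872 nM, and compound 2 gives 229 nM; the step of a 3.8-fold lower number from compound 1 to compound 2 (0.58 log units; beyond the scatter) shows that dimethylamino in place of propylamino on the carbonyl carbon lowered the number. Going by the values given here, compound 2 thus stands lowest of the two numbers measured so far.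

Compound 3 `CCN(Cc1ccccc1)Cc1nc2ccccc2c(-c2ccccc2)c1C(=O)N(C)c1ccccc1` carries the change (phenyl in place of methyl on an amide-type nitrogen). Among the compounds with values here, only the step from compound 1 to compound 2 touches the same amide, and it was modest; no measured pair shows a phenyl entering there, so the direction rests on little. A step of similar modest size, toward a lower number, is expected for compound 3, as a 1.9-fold lower number from compound 2 to compound 3 (0.28 log units; within the scatter). Compound 3 is therefore estimated to give 120 nM in this assay, with a range from 35 nM to 450 nM.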

Compound 3, half-maximal inhibitory concentration: 1320 nM
For compound 3 the middle estimate is 11-fold (1.04 log units) below the measured one; the measured number lies above the stated range.
By their numbers in this assay, from the lowest: compound 2; then compounds 1 and 3 (each within the scatter of the next).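

In this assay, going by these compounds alone, phenyl in place of methyl on the amide-type nitrogen gives a clear rise (a 5.8-fold higher number from compound 2 to compound 3 (0.76 log units; beyond the scatter)), so a change on this nitrogen can move the number up as well as down, and the single step from compound 1 to compound 2 gave no hint of this. Methyl(phenyl)amino and propylamino on the carbonyl carbon cannot be told apart (a 1.5-fold higher number from compound 1 to compound 3 (0.18 log units; within the scatter)), which leaves dimethylamino as the only one of these three amide groups that stands apart. Nothing available here explains why these numbers moved as they did.

Still open, as far as these compounds go, is whether the rise belongs to phenyl itself or would also appear with ethyl or benzyl on this nitrogen. A piperidine ring in place of dimethylamino, or a carboxylic acid in place of the whole amide, would show how far this position reaches beyond simple amides.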